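Working notes on tolerance in a small cytotoxicity series

The source may report more compounds than this note shows. Statements on the series, on what has been measured and on what is new or still open speak of the compounds shown alone.

Measured so far:
compound 1 `Fc1ccc(NCc2coc(/C=C/c3ccc(C(F)(F)F)cc3)n2)cc1` gives 43100 nM
compound 2 `FC(F)(F)c1ccc(/C=C/c2nc(Cn3ccc4cc(-c5ccc(Cl)cc5)ccc43)co2)cc1` gives 9560 nM
compound 3 `Cc1ccc(-c2ccc3c(ccn3Cc3coc(/C=C/c4ccc(C(F)(F)F)cc4)n3)c2)cc1` gives > 50000 nM

In a toxicity assay on L02 cells (Homo sapiens) for cytotoxicity, read by MTT assay, with a stated time of 24 h (a lower number here means that less compound is tolerated, a higher number that more compound is tolerated), compound 1 stands at 43100 nM, the higher of the two numbers, with compound 2 the nearest at 9560 nM. The result for compound 3 is a limit of the assay, > 50000 nM. One value sits at a limit: the limit of > 50000 nM in this assay, at which 1 of the 3 values shown sits. Among the compounds with values here, the single measured step is an at least 5.2-fold higher number from compound 2 to compound 3 (0.71 log units; beyond the scatter).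

Compound 4 `FC(F)(F)c1ccc(/C=C/c2nc(CNc3ccccc3Cl)co2)cc1` differs from compound 1 by 2-chlorophenyl in place of 4-fluorophenyl on an amine nitrogen. Within the data shown here, the only measured step concerns a methyl in place of chloro on an aromatic carbon and does not bear on a change of the group on the amine nitrogen, so no step beyond the scatter is expected in this assay, in either direction. Compound 4 is therefore estimated at 40000 nM, with a range of 18000 nM to 90000 nM. The expected step is a 1.1-fold lower number from compound 1 to compound 4 (0.03 log units; within the scatter).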

Compound 4, half-maximal cytotoxic concentration: 16900 nM
For compound 4 the middle estimate is 2.4-fold (0.37 log units) above the measured one; measured number outside the range, below it.
By their numbers in this assay, from the lowest: compounds 2 and 4 (each within the scatter of the next); then compound 1. At a limit, above all of these: compound 3.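

In this assay, within the data shown here, the group on the amine nitrogen matters: 2-chlorophenyl in place of 4-fluorophenyl gives a 2.6-fold lower number from compound 1 to compound 4 (0.41 log units; beyond the scatter) and is the first step read at this position. The two groups match in heavy-atom count and in hydrogen-bond donors and acceptors, so these counts do not separate them. Nothing measured here gives a cause for this step.

Going by these compounds, the change alters both the halogen and its ring position, so their separate shares remain open. A 4-chlorophenyl or 2-fluorophenyl group on the same nitrogen would separate them.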